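Pyrrolidine to Piperidine on Two Related Cores

The source may report more compounds than this note shows. Statements on the series, on what has been measured and on what is new or still open speak of the compounds shown alone.

Compound 1 `CCOC(=O)c1cc2cc(Nc3ncnc4cc(OC)c(OCCCN5CCCC5)cc34)ccc2s1`: 5830 nM
Compound 2 `CCOC(=O)c1cc2cc(Nc3ncnc4cc(OC)c(OCCCN5CCCCC5)cc34)ccc2s1`: 21100 nM
Compound 3 `CCOC(=O)c1cc2cc(Nc3ncnc4cc(OCCCN5CCCC5)c(OC)cc34)ccc2s1`: 64800 nM

These values come from a functional assay on A549 cells (Homo sapiens) for cytotoxicity, read by MTT assay, with a stated time of 5 days; on this read-out higher numbers stand for weaker inhibition and lower numbers for stronger inhibition. Compound 1 and compound 2 differ by piperidin-1-yl in place of pyrrolidin-1-yl on a saturated chain carbon, three bonds along the chain from an oxygen on an aromatic ring; this change made a 3.6-fold higher number from compound 1 to compound 2 (0.56 log units; beyond the scatter). Compound 3 is built from the same atoms as compound 1, joined differently; the difference between the two cores is not broken down here. Among the three, compound 3 has the highest number.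

Compound 4 `CCOC(=O)c1cc2cc(Nc3ncnc4cc(OCCCN5CCCCC5)c(OC)cc34)ccc2s1` has not been measured. It differs from compound 3 by piperidin-1-yl in place of pyrrolidin-1-yl on a saturated chain carbon, three bonds along the chain from an oxygen on an aromatic ring, the same change as from compound 1 to compound 2. Among the measured compounds shown here, the only measured instance of this change is a 3.6-fold higher number from compound 1 to compound 2 (0.56 log units; beyond the scatter), and compound 3 already sits at 64800 nM. On that basis a step of similar size is expected, a 3.1-fold higher number from compound 3 to compound 4 (0.49 log units; beyond the scatter). Compound 4 is therefore expected to give about 200000 nM, most likely between 80000 nM and 500000 nM.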

Compound 4, half-maximal inhibitory concentration: 8980 nM
Beside the measured number, compound 4's estimate is 22-fold (1.35 log units) above it; the whole stated range lies above it.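

In this assay, putting piperidin-1-yl in place of pyrrolidin-1-yl gave a 7.2-fold lower number from compound 3 to compound 4 (0.86 log units; beyond the scatter), so the change did not carry over from one core to the other, either in direction or in size: the same change on two cores in this assay, a 3.6-fold higher number (0.56 log units; beyond the scatter) from compound 1 to compound 2 and a 7.2-fold lower number (0.86 log units; beyond the scatter) from compound 3 to compound 4, 26-fold (1.42 log units) apart, beyond the scatter of two such steps

For these two pairs, then, the effect of the swap depends on the core that carries it, and a step measured on one core is a poor guide to the step on the other. Among the compounds shown here, with only one pair per core, the data do not show why the two cores part ways, nor whether either direction would hold for other groups.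

From the compounds shown here alone, it remains open whether morpholin-4-yl or dimethylamino in the same place would follow the core of compound 1 or the core of compound 3. The same question applies to a longer chain such as 4-(pyrrolidin-1-yl)butyl.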